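The source may hold more compounds than are shown below. What is called first, only, known or untested is meant among the compounds shown, and "the series" means these compounds.

Measured so far in an assay for binding affinity to dual specificity mitogen-activated protein kinase kinase 4 (Homo sapiens), read by KINOMEscan, tested at 100 nM; on this read-out higher numbers stand for a weaker effect at the one concentration tested and lower numbers for a stronger effect:

compound 1, `CCCS(=O)(=O)Nc1ccc(F)c(C(=O)c2n[nH]c3ncc(-c4ccccc4Cl)cc23)c1F`, gives 9.3%;
compound 2, `CCCS(=O)(=O)Nc1ccc(F)c(C(=O)c2n[nH]c3ncc(-c4cccc(Cl)c4)cc23)c1F`, gives 40%;
compound 3, `CCCS(=O)(=O)Nc1ccc(F)c(C(=O)c2n[nH]c3ncc(-c4ccc(C(C)(C)C)cc4)cc23)c1F`, gives 46%.

Compound 3 has the highest of the three numbers. Its nearest neighbour is compound 2: the step of a number 6 percentage points higher from compound 2 to compound 3 (within the scatter) lies within the scatter, so the two cannot be ordered. Compound 1 is farthest away, the step of a number 36.7 percentage points higher from compound 1 to compound 3 (beyond the scatter) being beyond the scatter, as is a number 30.7 percentage points higher from compound 1 to compound 2 (beyond the scatter).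

Compound 4, `CCCS(=O)(=O)Nc1ccc(F)c(C(=O)c2n[nH]c3ncc(-c4ccc(NS(C)(=O)=O)cc4)cc23)c1F`, differs from compound 3 in one place: methanesulfonamido in place of tert-butyl on an aromatic carbon. The step that bears most directly on it is a number 6 percentage points higher from compound 2 to compound 3 (within the scatter), which shows that exchanging one group on the pendant phenyl for another at a different place left the number within the scatter. The two large steps both start from compound 1 and concern the 2-chlorophenyl, which compound 4 does not carry. Among the measured compounds shown here, no measured step exchanges one group for another on the same carbon of the phenyl, so the expectation is uncertain. Compound 4 is therefore estimated to sit near compound 3, at 40%, with a plausible range from 15% to 75%. The expected step is a number 6 percentage points lower from compound 3 to compound 4 (within the scatter), not clearly beyond the scatter in either direction.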

Compound 4, a percentage reported as activity, at one concentration (the size of the read-out at that concentration, not a potency): 0.85%
For compound 4 the middle estimate is 39.2 percentage points above the measured one; the whole stated range lies above it.
By their numbers in this assay, from the lowest: compounds 4 and 1 (each within the scatter of the next); then compounds 2 and 3 (each within the scatter of the next).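

In this assay, among the compounds shown here, exchanging tert-butyl for methanesulfonamido on the same aromatic carbon of the pendant phenyl gave a number 45.2 percentage points lower from compound 3 to compound 4 (beyond the scatter) and thus showed for the first time that a change of group at one fixed carbon of this ring can move the number far beyond the scatter. The 4-(methanesulfonamido)phenyl group also separates from the 3-chlorophenyl group, with a number 39.2 percentage points lower from compound 2 to compound 4 (beyond the scatter) on record, while a number 8.5 percentage points lower from compound 1 to compound 4 (within the scatter) places it within the scatter of the 2-chlorophenyl group, so among these compounds a low number no longer belongs to the 2-chlorophenyl group alone. No measurement shown here offers an explanation for these differences.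

As far as these compounds go, it remains open whether an amine, a carboxylic acid or a methyl sulfone in place of methanesulfonamido on that carbon would give a number like that of compound 4, and whether methanesulfonamido would do the same on another carbon of the phenyl. From the compounds shown here alone, it also remains open whether the stronger and weaker effects seen here, each read at a single concentration, would hold at other concentrations or against other kinases.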